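A few compounds are considered here, and "the series" means these few. Any claim that something is new, unique, unknown or untested is made for them only; others in the source may bear on it.

Measured so far in a functional assay on MIA PaCa-2 cells (Homo sapiens) for antiproliferative activity, read by MTT assay, with a stated time of 72 h; on this read-out higher numbers stand for an effect only at larger amounts of compound and lower numbers for an effect already at smaller amounts:
- compound 1 `CNC(=O)c1cccc(Cn2nc(C)c(NC(=O)c3ccc(COC4CCCCC4)cc3)c2C)c1`: 14000 nM
- compound 2 `CNC(=O)c1cccc(Cn2nc(C)c(NC(=O)c3ccc(COc4cccc(OC)c4)cc3)c2C)c1`: 6200 nM

Compound 1 stands highest of the two numbers; its nearest neighbour is compound 2, reached by a 2.3-fold lower number from compound 1 to compound 2 (0.35 log units; beyond the scatter) with 3-methoxyphenyl in place of cyclohexyl on an oxygen on a saturated carbon.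

Compound 3 `CNC(=O)c1cccc(Cn2nc(C)c(NC(=O)c3ccc(COc4ccc(C(F)(F)F)cc4C)cc3)c2C)c1` is not yet measured. Against compound 1 it differs by 2-methyl-4-(trifluoromethyl)phenyl in place of cyclohexyl on an oxygen on a saturated carbon. Among the measured compounds shown here, the only step that bears on this change is a 2.3-fold lower number from compound 1 to compound 2 (0.35 log units; beyond the scatter), which also replaces cyclohexyl on that oxygen with an aromatic ring; it was modest but beyond the scatter, toward a lower number. The entering ring here carries different substituents, so the size of the shift cannot be read closely, but a step of similar direction and roughly similar size in this assay is expected, giving a 2.5-fold lower number from compound 1 to compound 3 (0.41 log units; beyond the scatter). For compound 3 the expected value is therefore 5500 nM, with a range from 2200 nM to 14000 nM.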

Compound 3, half-maximal effective concentration: 620 nM
Beside the measured number, compound 3's estimate is 8.9-fold (0.95 log units) above it; measured number outside the range, below it.
By their numbers in this assay, from the lowest: compound 3; then compound 2; then compound 1.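

At the group on the oxygen on a saturated carbon, the change from cyclohexyl to 2-methyl-4-(trifluoromethyl)phenyl gives a 23-fold lower number from compound 1 to compound 3 (1.35 log units; beyond the scatter) in this assay and shows that this position can move the number much further than the step to 3-methoxyphenyl had indicated. An aromatic ring in this place does not fix the outcome by itself: exchanging one substituted ring for another gives a 10-fold lower number from compound 2 to compound 3 (1.00 log units; beyond the scatter) and shows that the ring's substituents matter in this assay as well. Nothing available explains the size of these steps.

Compound 3 carries the methyl and the trifluoromethyl together, and which of them accounts for the step stays open. Also open, as far as these compounds go, is how the number would read with an unsubstituted phenyl, or with an amine or a carboxylic acid on the ring.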